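Methoxy in Place of Methyl: What to Expect

The compounds below may be only part of what the source reports. "The series", "measured", "known", "first", "only" and "open" are said of these compounds alone.

Among the measured compounds shown here, compound 2 `Cc1ccc(-c2nc3ccccc3s2)cc1NC(=O)c1cc([N+](=O)[O-])c(N2CCC(C(=O)O)CC2)cc1Cl` gives the only number in an ADME assay for permeability, using PAMPA, at pH 7.4 (on this read-out lower numbers stand for lower permeability and higher numbers for higher permeability), namely 17 10^-6 cm/s. Compound 1 `Cc1ccc(-c2nc3ccccc3s2)cc1NC(=O)c1cc([N+](=O)[O-])c(N2CCCCC2)cc1Cl` sits at a limit of this assay, < 1 10^-6 cm/s. Compound 3 `COc1ccc(-c2nc3ccccc3s2)cc1NC(=O)c1cc([N+](=O)[O-])c(N2CCC(C(=O)O)CC2)cc1Cl` differs from compound 2 in one place: methoxy in place of methyl on an aromatic carbon. For the measured compounds named here, the single measured step, an at least 17-fold higher number from compound 1 to compound 2 (1.23 log units; beyond the scatter), concerns a change at a saturated ring carbon and does not bear on this exchange on the aromatic ring; no measured step does. For compound 3 a step within the usual scatter is therefore expected, a 1.2-fold lower number from compound 2 to compound 3 (0.08 log units; within the scatter), giving an estimate of 14 10^-6 cm/s with a range from 6 10^-6 cm/s to 32 10^-6 cm/s.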

Compound 3, apparent permeability in the ADME assay: 5 10^-6 cm/s
The estimate for compound 3 lay 2.8-fold (0.45 log units) above the measured number; measured number below the stated range.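

In the ADME assay, the exchange of methyl for methoxy on this aromatic carbon, ortho to a large group and para to a 1,3-benzothiazol-2-yl group, is not silent: the result is a 3.4-fold lower number from compound 2 to compound 3 (0.53 log units; beyond the scatter). The same exchange also shows in a second read-out: in a physicochemical assay for solubility, read by spectrophotometry, in phosphate buffer, measured as kinetic solubility, with a stated time of 18 h, at pH 7.4 (on this read-out lower numbers stand for lower solubility and higher numbers for higher solubility), compound 2 gives 590 nM and compound 3 gives 210 nM. This position therefore responds to a small change, and both numbers fall together with it.

Going by these compounds, whether other groups here, such as ethoxy, a chlorine atom or an amine, lower both numbers as well remains open. The compounds shown also do not tell why the numbers fall.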